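The source may hold more compounds than are shown below. What is called first, only, known or untested is meant among the compounds shown, and "the series" means these compounds.

Two measured compounds set the scale here. Compound 1 `Cc1cccc(-n2cc(-c3cccc(NS(=O)(=O)c4c[nH]c(=O)[nH]c4=O)c3)nn2)c1` gives 18500 nM in an ADME assay on GES1 cells (Homo sapiens) for cytotoxicity, read by MTT assay, with a stated time of 24 h (on this read-out higher numbers stand for lower toxicity in this test and lower numbers for higher toxicity in this test), and compound 2 `Cc1ccc(-n2cc(-c3cccc(NS(=O)(=O)c4c[nH]c(=O)[nH]c4=O)c3)nn2)cc1` gives 15800 nM in this assay. Among the measured compounds shown here, the only change between them is a 4-methylphenyl in place of a 3-methylphenyl on an aromatic nitrogen, and a 1.2-fold lower number from compound 1 to compound 2 (0.07 log units; within the scatter) shows that moving the methyl group around the ring did not shift the read-out beyond its scatter.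

Compound 3 `O=c1[nH]cc(S(=O)(=O)Nc2cccc(-c3cn(-c4cccc(F)c4)nn3)c2)c(=O)[nH]1` carries a fluorine instead of a methyl on that phenyl ring. In this assay compound 3 was recorded as "not toxic" (no number reported), so no number stands for it, only the statement that no toxicity was seen.

Compound 4 `O=c1[nH]cc(S(=O)(=O)Nc2cccc(-c3cn(-c4ccc(F)cc4)nn3)c2)c(=O)[nH]1` differs from compound 3 by 4-fluorophenyl in place of 3-fluorophenyl on an aromatic nitrogen. The change from compound 1 to compound 2 is the closest parallel: the same swap of ring position with a methyl group rather than a fluorine, and it stayed within the scatter. On that basis no step beyond the scatter is expected from compound 3 to compound 4 in this assay, and since compound 3 gave no number, the estimate rests on the two measured values as a floor. Compound 4 is therefore expected to give about 40000 nM in this assay, within a range of 15000 nM to 150000 nM, with a fair chance that it is again reported only as not toxic.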

Compound 4, half-maximal cytotoxic concentration: "not toxic" (no number reported)
Compound 4: no number reported; there is nothing to compare the estimate with.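

Compound 3 and compound 4 are both recorded only as not toxic in this assay, with no number, so no step can be read from the 3-fluorophenyl to the 4-fluorophenyl. No measurement shown gives a reason for this result. Going by these compounds, whether moving the fluorine changes the toxicity seen in this test stays open.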